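A Fluoro Added to Compound 1

The source may hold more compounds than are shown below. What is called first, only, known or untested is meant among the compounds shown, and "the series" means these compounds.

Measured so far in an ADME assay on microsomes from liver (Canis lupus familiaris) for metabolic stability, with a stated time of 10 min (a higher number here means that more of the compound is left, a lower number that less of the compound is left), are these compounds:
compound 1 `FC(F)(F)c1ccccc1-c1ccc2[nH]c(C3=NOC4(CCCCC4)C3)nc2c1` gives 71% of the compound left
compound 2 `FC(F)(F)Oc1ccccc1-c1ccc2[nH]c(C3=NOC4(CCCCC4)C3)nc2c1` gives 81% of the compound left
compound 3 `FC(F)Oc1ccccc1-c1ccc2[nH]c(C3=NOC4(CCCCC4)C3)nc2c1` gives 81% of the compound left

On these numbers, compound 1 cannot be separated from the other two. Trifluoromethoxy in place of its trifluoromethyl gave a number 10 percentage points higher from compound 1 to compound 2 (within the scatter) and difluoromethoxy in that place gave a number 10 percentage points higher from compound 1 to compound 3 (within the scatter) in the same test. Compound 4 `Fc1cccc(C(F)(F)F)c1-c1ccc2[nH]c(C3=NOC4(CCCCC4)C3)nc2c1` keeps the trifluoromethyl and carries fluoro in place of hydrogen on an aromatic carbon as fluoro in place of hydrogen on an aromatic carbon. Among the compounds with values here, no measured step adds fluoro to an aromatic carbon. The nearest exchange, hydrogen in place of fluoro on a saturated chain carbon, gave no change at the digits printed from compound 2 to compound 3 (within the scatter) in this test. No change beyond the scatter is therefore expected, and the estimated step is a number 4 percentage points higher from compound 1 to compound 4 (within the scatter) in this test. In this assay compound 4 is expected at 75% within a range of 60% to 88% when measured.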

Compound 4, percent of the compound remaining: 65%
Estimate against measurement, compound 4: 10 percentage points above; low and high end bracket the measured number.
By their numbers in this assay, from the lowest: compounds 4, 1, 2 and 3 (each within the scatter of the next, the first and the last beyond it).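

In this assay, fluoro in place of hydrogen on an aromatic carbon, ortho to a large group and meta to a trifluoromethyl group, gave a number 6 percentage points lower from compound 1 to compound 4 (within the scatter) and so cannot be told apart from the scatter. This is the first step shown at this position of the ring, and here the added fluoro leaves compound 4 level with compound 1 on this read-out. Nothing measured here points to a cause for this step.

From the compounds shown here alone, whether an amine or a methoxy group on this same carbon would give a step beyond the scatter stays open. So does whether fluoro here would behave the same with trifluoromethoxy in place of the trifluoromethyl.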